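Swapping a Saturated Ring for a Bromothiophene Arm

A few compounds are considered here, and "the series" means these few. Any claim that something is new, unique, unknown or untested is made for them only; others in the source may bear on it.

Of the compounds shown here, two of a shared core have been tested in an ADME assay on A549 cells (Homo sapiens) for cytotoxicity, read by resazurin assay, with a stated time of 48 h; on this read-out higher numbers stand for lower toxicity in this test and lower numbers for higher toxicity in this test. Going by the values given here, compound 1 `CC(C)CNc1ccc(NC(=O)c2cc(Cl)ccc2O)c(Cl)c1` gives 60000 nM, while compound 2 `CC1(Nc2ccc(NC(=O)c3cc(Cl)ccc3O)c(Cl)c2)CCCC1` gives 157000 nM, so compound 2 holds the higher of the two numbers, with compound 1 as its only neighbour. Among the compounds with values here, the single step between them, a 2.6-fold higher number from compound 1 to compound 2 (0.42 log units; beyond the scatter), came with 1-methylcyclopentyl in place of isobutyl on a nitrogen on an aromatic ring.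

Compound 3 `O=C(Nc1ccc(NCc2ccc(Br)s2)cc1Cl)c1cc(Cl)ccc1O` differs from compound 2 at the same nitrogen: (5-bromothiophen-2-yl)methyl in place of 1-methylcyclopentyl on a nitrogen on an aromatic ring. Within the data shown here, no measured step involves an aromatic group at this position, so the earlier step offers only a rough sense of scale, showing that changes here moved this assay modestly. For compound 3 a step of a 2.0-fold lower number from compound 2 to compound 3 (0.29 log units; within the scatter) is therefore expected, with little confidence in its direction. Compound 3 is estimated at 80000 nM, within 25000 nM to 250000 nM.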

Compound 3, half-maximal cytotoxic concentration: 20700 nM
Compound 3: the middle estimate sits 3.9-fold (0.59 log units) above what was measured, and the stated range ends above it.
By their numbers in this assay, from the lowest: compound 3; then compound 1; then compound 2.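

Unlike compound 1 and compound 2, compound 3 carries an aromatic ring in the group on this nitrogen, and the read-out moves the opposite way from the earlier step: this assay shows a 7.6-fold lower number from compound 2 to compound 3 (0.88 log units; beyond the scatter), which here stands for higher toxicity in this test. The open-chain comparison points the same way, with a 2.9-fold lower number from compound 1 to compound 3 (0.46 log units; beyond the scatter), so this position can shift the number in either direction, and compound 3 now has the lowest number of the three. Nothing measured here explains the drop.

The change brings in a thiophene ring, a sulfur and a bromine together, so these compounds cannot show which part goes with the lower number. A thiophen-2-ylmethyl group without the bromine, or a benzyl group, on this nitrogen would help separate those parts.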